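The source may hold more compounds than are shown below. What is called first, only, known or untested is meant among the compounds shown, and "the series" means these compounds.

Measured compounds:
- Compound 1, `O=C(Nc1cc(C(F)(F)F)cc(C(F)(F)F)c1)C1NCCc2ccccc21`: > 10000 nM
- Compound 2, `O=C(Nc1ccc(C(F)(F)F)cc1)C1c2ccccc2CCN1C(=O)c1ccc(Cl)cc1`: 4200 nM
- Compound 3, `O=C(Nc1ccc(C(F)(F)F)cc1)C1NCCc2ccccc21`: 4220 nM

In a functional assay on NUGC-3 cells (Homo sapiens) for inhibition, read by sulforhodamine B assay, with a stated time of 48 h (on this read-out higher numbers stand for weaker inhibition of growth and lower numbers for stronger inhibition of growth), compound 2 gives 4200 nM. Compound 3, which differs from it only at the ring amine nitrogen, gives 4220 nM in this assay, and the step of a 1.0-fold higher number from compound 2 to compound 3 (0.00 log units; within the scatter) lies within the scatter. Compound 1 is reported only as a limit of this assay, > 10000 nM, and its trifluoromethyl pattern differs from both of the others, so it cannot be placed against them by a single step. Among the two plain numbers, compound 2 stands lowest, yet its nearest neighbour, compound 3, is so close that no order between them can be read.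

Compound 4, `O=C(Nc1cccc(C(F)(F)F)c1)C1c2ccccc2CCN1C(=O)c1ccc(Cl)cc1`, has not been measured. It differs from compound 2 by 3-(trifluoromethyl)phenyl in place of 4-(trifluoromethyl)phenyl on an amide-type nitrogen: the trifluoromethyl group moves to a different position on the same ring, with all atoms kept. Going by the values given here, no measured step touches this kind of move, and the only measured step, from compound 2 to compound 3, concerns another part of the molecule and was flat.

With no evidence pointing either way, compound 4 is expected to sit close to compound 2, with a step of a 1.2-fold higher number from compound 2 to compound 4 (0.08 log units; within the scatter) in this assay, which is no change beyond the scatter. The estimate for compound 4 is 5000 nM, with a range from 1500 nM to 15000 nM.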

Compound 4, concentration for 50% growth inhibition: > 10000 nM
Compound 4: a limit, no number (the forecaster's own chance of this, stated with the estimate: 25%); at least 2.0-fold (0.30 log units) between middle value and limit.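

Moving the trifluoromethyl group on the ring attached to the amide-type nitrogen is the first change at this place that can be read, and in this assay it is not neutral: the result is an at least 2.3-fold higher number from compound 2 to compound 4 (0.37 log units; beyond the scatter). The earlier step at the ring amine nitrogen, a 1.0-fold higher number from compound 2 to compound 3 (0.00 log units; within the scatter), showed no change that could be read, whereas here a change in where one group sits on the same ring weakens growth inhibition, even though all atoms are kept. The result for compound 4 is a limit and not a number: the limit of > 10000 nM in this assay, at which 2 of the 4 values shown sit.

The compounds shown leave open whether a chlorine atom, a nitrile or a methoxy group in place of the trifluoromethyl group would keep the level of compound 2 or fall away as compound 4 does. They also leave open whether 3-(trifluoromethyl)phenyl has the same effect when the ring amine nitrogen carries hydrogen, as in compound 3, rather than (4-chlorophenyl)carbonyl, or when it carries a small acetyl group or a longer alkyl chain.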